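The compounds below may be only part of what the source reports. "The series", "measured", "known", "first", "only" and "open" are said of these compounds alone.

Among the compounds with values here, in a functional assay on MCF7 cells (Homo sapiens) for inhibition (on this read-out higher numbers stand for weaker inhibition and lower numbers for stronger inhibition), compound 1 `O=C(CC(CC(=O)NC1Cc2ccccc2C1)c1ccc(Cl)cc1)NCCN1CCCCC1` gives 35500 nM, the higher of the two numbers so far, and compound 2 `CCN(C(=O)CC(CC(=O)NCCN1CCCCC1)c1ccc(Cl)cc1)C1Cc2ccccc2C1` gives 16500 nM. Compound 3 `Cc1ccc(C(CC(=O)NCCN2CCCCC2)CC(=O)NC2Cc3ccccc3C2)cc1` departs from compound 1 on the aromatic ring: methyl in place of chloro on an aromatic carbon. In words, this is methyl in place of chloro on an aromatic carbon, turning 4-chlorophenyl into 4-methylphenyl.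

Within the data shown here, the only measured step, a 2.2-fold lower number from compound 1 to compound 2 (0.33 log units; beyond the scatter), is modest and comes from ethyl in place of hydrogen on an amide-type nitrogen. Among the measured compounds shown here, it therefore says nothing direct about the aromatic position, and no measured compound supports a direction there. No step beyond the scatter is expected in this assay. The estimated step is a 1.1-fold higher number from compound 1 to compound 3 (0.05 log units; within the scatter). For compound 3 the expected value is 40000 nM, with an estimated range of 18000 nM to 85000 nM.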

Compound 3, half-maximal inhibitory concentration: > 100000 nM
Compound 3 was reported as a limit; the forecaster's own chance of this, stated with the estimate: 15%; middle value at least 2.5-fold (0.39 log units) away from the limit.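

Replacing chloro with methyl on the aromatic carbon gives an at least 2.8-fold higher number from compound 1 to compound 3 (0.44 log units; beyond the scatter), so in this assay this position responds to a change of a single heavy atom, which the earlier step on the amide-type nitrogen could not show. Compound 3 is recorded only as a limit, > 100000 nM, not as a number. The step therefore has a floor but no measured size: the limit of > 100000 nM in this assay, at which 1 of the 3 values shown sits.

With only chloro and methyl shown at this position, a single pair cannot separate a benefit of chloro from a penalty of methyl, and fluoro, bromo or methoxy on the same aromatic carbon would help to separate them. Going by these compounds, it also remains open whether ethyl on the amide-type nitrogen, as in compound 2, has any effect alongside 4-methylphenyl.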